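The source may hold more compounds than are shown below. What is called first, only, known or untested is meant among the compounds shown, and "the series" means these compounds.

Measured in a functional assay on RAW264.7 cells (Mus musculus) for cytotoxicity, read by MTT assay, with a stated time of 48 h, tested at 50 uM; on this read-out higher numbers stand for a stronger effect at the one concentration tested and lower numbers for a weaker effect:
Compound 1 `CS(=O)(=O)c1ccc(Cc2nnc3n2N=C(c2ccc(-c4ccccc4)cc2)CS3)cc1` gives 67.9%.
Compound 2 `CS(=O)(=O)c1ccc(Cc2nnc3n2N=C(c2cc(Cl)sc2S(N)(=O)=O)CS3)cc1` gives 27.5%.
Compound 3 `CS(=O)(=O)c1ccc(Cc2nnc3n2N=C(c2cc(Cl)sc2Cl)CS3)cc1` gives 25.5%.

Compound 3 stands lowest of the three numbers, though its gap to compound 2 lies within the scatter; only compound 1 sits clearly higher. The next compound, compound 4 `CS(=O)(=O)c1ccc(Cc2nnc3n2N=C(c2ccc(O)c(C(N)=O)c2)CS3)cc1`, carries the change (3-carbamoyl-4-hydroxyphenyl in place of 2,5-dichlorothiophen-3-yl on a carbon with a double bond to nitrogen). Among the compounds with values here, the one measured step, a number 2 percentage points lower from compound 2 to compound 3 (within the scatter), touches a different ring and a different pair of groups, so no step bears directly on this exchange. The spread between compound 1 and compound 3 shows that the group on this carbon can move the read-out beyond the scatter, but gives no direction for this new group. The expected step of a number 9.5 percentage points higher from compound 3 to compound 4 (within the scatter) is therefore modest and uncertain. Compound 4 is estimated at 35%, within 15% to 60%.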

Compound 4, a percentage reported as activity, at one concentration (the size of the read-out at that concentration, not a potency): 33.1%
Beside the measured number, compound 4's estimate is 1.9 percentage points above it, and the stated range covers the measured number.
By their numbers in this assay, from the lowest: compounds 3, 2 and 4 (each within the scatter of the next); then compound 1.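

In this assay, 3-carbamoyl-4-hydroxyphenyl in place of 2,5-dichlorothiophen-3-yl gives a number 7.6 percentage points higher from compound 3 to compound 4 (within the scatter), and in place of 5-chloro-2-sulfamoylthiophen-3-yl it gives a number 5.6 percentage points higher from compound 2 to compound 4 (within the scatter). A six-membered aromatic ring of carbon only at this position is therefore not enough on its own to reach the level of compound 1 at 67.9%. No supporting data bear on this result.

The compounds shown do not separate the contributions of the carbamoyl and the hydroxy group. Going by these compounds, what an amine or a carboxylic acid on this phenyl ring would give remains open.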